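Adding a Third Methoxy Group: An Expected Small Step

A few compounds are considered here, and "the series" means these few. Any claim that something is new, unique, unknown or untested is made for them only; others in the source may bear on it.

Three measured compounds share one core and differ only in the ring attached to a saturated ring carbon. Compound 1 `NS(=O)(=O)c1ccc(N2N=C(c3cccc(O)c3)C[C@H]2c2ccc(Cl)cc2)cc1` carries a 4-chlorophenyl there, and in a functional assay on the whole organism (strain Wistar albino) for inhibition, with Rattus norvegicus as the target, read by paw edema, with stated times of 30 min and 3 h, at a dose of 0.05 mmol/kg (on this read-out lower numbers stand for less inhibition and higher numbers for more inhibition at the one dose given (going by the name of the read-out)), compound 1 gives 19.2%. Compound 2 `NS(=O)(=O)c1ccc(N2N=C(c3cccc(O)c3)C[C@H]2c2ccc(O)cc2)cc1`, with a 4-hydroxyphenyl, gives 64.7%, while compound 3 `COc1ccc([C@@H]2CC(c3cccc(O)c3)=NN2c2ccc(S(N)(=O)=O)cc2)cc1OC`, with a 3,4-dimethoxyphenyl, gives 55.9%. Compound 3 stands second highest of the three numbers: the step is a number 36.7 percentage points higher from compound 1 to compound 3 (beyond the scatter), but a number 8.8 percentage points lower from compound 2 to compound 3 (within the scatter), so compound 2 and compound 3 cannot be told apart on this read-out.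

Compound 4 `COc1cc([C@@H]2CC(c3cccc(O)c3)=NN2c2ccc(S(N)(=O)=O)cc2)cc(OC)c1OC` makes one further change: methoxy in place of hydrogen on an aromatic carbon. The new methoxy sits on the same six-membered aromatic ring of carbon only, ortho to a methoxy group and meta to a methoxy group. Among the compounds with values here, no measured step adds a methoxy where a hydrogen stood; the steps of a number 45.5 percentage points higher from compound 1 to compound 2 (beyond the scatter) and a number 36.7 percentage points higher from compound 1 to compound 3 (beyond the scatter) exchange whole groups, and the only step between two methoxy-bearing or hydroxy-bearing rings stayed within the scatter. The expectation is therefore no step beyond the scatter. For compound 4 the estimated value is 55%, within 40% to 70%. This amounts to an expected a number 0.9 percentage points lower from compound 3 to compound 4 (within the scatter).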

Compound 4, a percentage reported as inhibition, in the whole organism at one dose (the size of the read-out at that dose, not a potency): 51.9%
Beside the measured number, compound 4's estimate is 3.1 percentage points above it; low and high end bracket the measured number.
By their numbers in this assay, from the lowest: compound 1; then compounds 4, 3 and 2 (each within the scatter of the next, the first and the last beyond it).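

In this assay, methoxy in place of hydrogen on this aromatic carbon gives a number 4 percentage points lower from compound 3 to compound 4 (within the scatter), so this change leaves the two compounds indistinguishable on this read-out. The earlier steps shown here exchanged whole groups, whereas this one isolates a single added methoxy, ortho to a methoxy group and meta to a methoxy group, and shows that on this ring such an addition produces no step beyond the scatter. No available evidence bears on why the number behaves this way.

The compounds shown leave open how an amine, a carboxylic acid or a chain longer than methoxy would read at this same aromatic carbon. They also leave open whether adding methoxy would give so small a step on the 4-chlorophenyl ring of compound 1.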